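This account rests on a few compounds, and the source may have more. Where it says the series, first, only, none or still open, it means among the compounds named here.

The compounds here share one core and differ in the group on an amide-type nitrogen. In a functional assay on HCT-116 cells (Homo sapiens) for cytotoxicity (on this read-out higher numbers stand for weaker inhibition and lower numbers for stronger inhibition), compound 1 `CCNC(=O)c1cc2[nH]nc(NC(=O)c3ccc(N4CCN(C)CC4)cc3)c2s1`, which carries ethyl, gives 710 nM. Compound 2 `CN1CCN(c2ccc(C(=O)Nc3n[nH]c4cc(C(=O)Nc5ccccc5)sc34)cc2)CC1` is reported as "not active" (no number reported), with no number to compare. Among the compounds with values here, compound 3 `CN1CCN(c2ccc(C(=O)Nc3n[nH]c4cc(C(=O)NC5CCc6ccccc65)sc34)cc2)CC1`, which carries 2,3-dihydro-1H-inden-1-yl, gives 1400 nM, and its only numerical neighbour is compound 1, within the scatter.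

Compound 4 `CC(C)NC(=O)c1cc2[nH]nc(NC(=O)c3ccc(N4CCN(C)CC4)cc3)c2s1` brings one change: isopropyl in place of 2,3-dihydro-1H-inden-1-yl on an amide-type nitrogen, in words, isopropyl in place of 2,3-dihydro-1H-inden-1-yl on an amide-type nitrogen. Within the data shown here, one measured step bears on this, a 2.0-fold higher number from compound 1 to compound 3 (0.29 log units; within the scatter), a swap at the same nitrogen that stays within the scatter. Isopropyl is a small chain like the ethyl of compound 1, so a value near that of compound 1 seems likely. Compound 2 is the warning that a change at this nitrogen can cost all measurable activity in this assay.

The expected move is small: the estimate is a 1.8-fold lower number from compound 3 to compound 4 (0.24 log units; within the scatter), which stays within the scatter. For compound 4 the estimated value is 800 nM, with an expected range of 300 nM to 2500 nM.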

Compound 4, half-maximal inhibitory concentration in the HCT-116 assay: 820 nM
Estimate against measurement, compound 4: 1.0-fold (0.01 log units) below; the range from low to high includes it.
By their numbers in the HCT-116 assay, from the lowest: compounds 1, 4 and 3 (each within the scatter of the next).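

In the HCT-116 assay, isopropyl on this amide-type nitrogen makes no difference that can be read, either against the larger 2,3-dihydro-1H-inden-1-yl, a 1.7-fold lower number from compound 3 to compound 4 (0.23 log units; within the scatter), or against ethyl, a 1.2-fold higher number from compound 1 to compound 4 (0.06 log units; within the scatter). In a physicochemical assay for solubility, at pH 7 (a higher number here means a more soluble compound, a lower number a less soluble compound), compound 3 gives < 1000 nM, which is a limit of the assay and not a number. In the physicochemical assay compound 4 gives 59000 nM. The same change that is silent on cytotoxicity is a large step in solubility: the measured solubility of compound 3, < 1000 nM, and of compound 4, 59000 nM, an at least 59-fold higher number (1.77 log units; beyond the scatter)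

The compounds shown leave open how the HCT-116 assay would respond to an amine, a carboxylic acid or a longer chain on this nitrogen. They also leave open whether the result of compound 4 in the physicochemical assay belongs to isopropyl itself or would hold for other groups without a ring.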